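Urea versus amide on a pyrazole series: weakening by one trifluoromethyl

The source may report more compounds than this note shows. Statements on the series, on what has been measured and on what is new or still open speak of the compounds shown alone.

Measured so far:
compound 1 `COc1cc(Cl)cc(-c2nn(-c3cccc(NC(=O)c4ccc(Cl)c(Cl)c4)c3)cc2-c2ccncc2)c1`: 84.6%
compound 2 `COc1cc(Cl)cc(-c2nn(-c3cccc(NC(=O)Nc4cc(C(F)(F)F)cc(C(F)(F)F)c4)c3)cc2-c2ccncc2)c1`: 11%

In a functional assay on NCI-H322M cells (Homo sapiens) for inhibition, read by sulforhodamine B assay, with a stated time of 48 h, tested at 10 uM (on this read-out lower numbers stand for a stronger effect and higher numbers for a weaker effect at the one concentration tested), compound 2 gives 11%, the lowest of the two numbers shown. Its nearest neighbour is compound 1, whose value in this assay sits higher by a gap beyond the scatter.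

Compound 3 `COc1cc(Cl)cc(-c2nn(-c3cccc(NC(=O)Nc4cccc(C(F)(F)F)c4)c3)cc2-c2ccncc2)c1` has not been measured. It differs from compound 2 by hydrogen in place of trifluoromethyl on an aromatic carbon, on an aromatic carbon meta to a trifluoromethyl group. For the measured compounds named here, no step between measured compounds mirrors this change. A weakening step from compound 2 is expected, a number 27 percentage points higher from compound 2 to compound 3 (beyond the scatter), beyond the scatter. Compound 3 is estimated at 38%, within 10% to 80%.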

Compound 3, a percentage reported as activity, at one concentration (the size of the read-out at that concentration, not a potency): 26.2%
Compound 3: the middle estimate sits 11.8 percentage points above what was measured; the measured number falls inside the stated range.
By their numbers in this assay, from the lowest: compound 2; then compound 3; then compound 1.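

In this assay hydrogen in place of trifluoromethyl on the aromatic carbon is only a modest step (a number 15.2 percentage points higher from compound 2 to compound 3 (beyond the scatter)), though beyond the scatter, so this position tolerates losing that group with part of the effect lost. With a single trifluoromethyl left, (3-(trifluoromethyl)phenyl)amino in place of 3,4-dichlorophenyl on the carbonyl carbon remains a large step (a number 58.4 percentage points lower from compound 1 to compound 3 (beyond the scatter)), so the second trifluoromethyl is not needed for most of that gain. From the compounds shown here alone, whether a methoxy, a nitrile or an amine at this position would match trifluoromethyl or hydrogen remains open. Nothing at hand explains either step.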